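Solubility across a shared core with two aryl variants

The source may report more compounds than this note shows. Statements on the series, on what has been measured and on what is new or still open speak of the compounds shown alone.

Three compounds in the series carry the same core with different substituents at two positions. Compound 2 `COc1ccc(F)cc1CNCCCNc1ccnc2cc(-c3ccc(C(F)(F)F)cc3)ccc12` and compound 3 `COc1cccc(CNCCCNc2ccnc3cc(-c4ccc(C(F)(F)F)cc4)ccc23)c1O` share the 4-(trifluoromethyl)phenyl group; compound 1 `COc1ccc(F)cc1CNCCCNc1ccnc2cc(Cc3ccccc3)ccc12` shares the amine-side group of compound 2 but carries benzyl instead. In a physicochemical assay for solubility, with a stated time of 18 h, at pH 7.4 (on this read-out higher numbers stand for higher solubility and lower numbers for lower solubility), compound 2 gives 32000 nM, and in this assay compound 3 gives 32000 nM, so that no change at the digits printed from compound 2 to compound 3 (within the scatter). The two cores differ only by 2-hydroxy-3-methoxyphenyl in place of 5-fluoro-2-methoxyphenyl on a saturated chain carbon bound to an amine nitrogen. In this assay compound 1 gives 4200 nM, which means a 7.6-fold lower number from compound 2 to compound 1 (0.88 log units; beyond the scatter); the change behind this step is benzyl in place of 4-(trifluoromethyl)phenyl on an aromatic carbon.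

Compound 4 `COc1cccc(CNCCCNc2ccnc3cc(Cc4ccccc4)ccc23)c1O` is not yet measured in this assay. It differs from compound 3 by benzyl in place of 4-(trifluoromethyl)phenyl on an aromatic carbon, the same change as from compound 2 to compound 1, at the same place on the core. For the measured compounds named here, the only guide is the single measured instance of this change, so the expectation for compound 4 rests on the step of a 7.6-fold lower number from compound 2 to compound 1 (0.88 log units; beyond the scatter) applied to the value of compound 3, 32000 nM. The step from compound 3 to compound 4 is estimated as a 7.6-fold lower number from compound 3 to compound 4 (0.88 log units; beyond the scatter). For compound 4 the expected solubility in this assay is 4200 nM, with an estimated range from 1500 nM to 12000 nM; with one prior example of the change, the uncertainty is wider than the scatter alone.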

Compound 4, solubility: 4200 nM
Compound 4: middle estimate and measured number agree at the digits printed; measured number inside the range.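

In this assay, benzyl in place of 4-(trifluoromethyl)phenyl gives a 7.6-fold lower number from compound 3 to compound 4 (0.88 log units; beyond the scatter), the same size of step as a 7.6-fold lower number from compound 2 to compound 1 (0.88 log units; beyond the scatter), so the change carries over unaltered at the digits printed from the core of compound 2 to the core of compound 3. The other change, 2-hydroxy-3-methoxyphenyl in place of 5-fluoro-2-methoxyphenyl, gives no change at the digits printed from compound 1 to compound 4 (within the scatter), matching no change at the digits printed from compound 2 to compound 3 (within the scatter), so across these four compounds the number follows the group on the aromatic carbon and the two changes add without any visible interaction. For the compounds shown here, this rests on only two pairs in one assay and says nothing about other amine-side groups, and nothing measured here bears on why the number moves with this change.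

Still open, from the compounds shown here alone, is which part of the change carries the step, since a plain phenyl on the same aromatic carbon would separate the loss of the trifluoromethyl group from the switch to benzyl. Also open, going by these compounds, is whether the step keeps its size with a carboxylic acid on that aryl group or with a longer chain on the amine side.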